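The source may hold more compounds than are shown below. What is called first, only, known or untested is meant among the compounds shown, and "the series" means these compounds.

Measured so far:
Compound 2, `COc1cc2c(Oc3ccc(NC(=O)c4cc(-c5ccccc5)ccn4)cc3F)ccnc2cc1OCCCN1CCCCC1`: 270 nM
Compound 1, `COc1cc2c(Oc3ccc(NC(=O)c4cc(-c5ccc(F)cc5)ccn4)cc3F)ccnc2cc1OCCCN1CCCCC1`: 1370 nM

In a functional assay on HT-29 cells (Homo sapiens) for cytotoxicity, read by MTT assay, with a stated time of 72 h (on this read-out higher numbers stand for weaker inhibition and lower numbers for stronger inhibition), compound 2 stands at the lower of the two numbers. Going by the values given here, the one measured step, a 5.1-fold lower number from compound 1 to compound 2 (0.71 log units; beyond the scatter), shows that taking a fluoro off the phenyl group and leaving hydrogen there gave the lower, stronger number. Compound 3, `COc1cc2c(Oc3ccc(NC(=O)c4cc(-c5ccc(C)cc5)ccn4)cc3F)ccnc2cc1OCCCN1CCCCC1`, differs from compound 2 by methyl in place of hydrogen on an aromatic carbon. This change runs in the opposite sense to that step, putting a small group back onto the phenyl ring where compound 2 carries hydrogen. Methyl is not fluoro, so the step cannot simply be read in reverse, but because the step of a 5.1-fold lower number from compound 1 to compound 2 (0.71 log units; beyond the scatter) was beyond the scatter, a move back toward a higher number is expected. Compound 3 is therefore expected to give 600 nM, within a range of 250 nM to 1500 nM. The expected step is a 2.2-fold higher number from compound 2 to compound 3 (0.35 log units; beyond the scatter).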

Compound 3, half-maximal inhibitory concentration: 340 nM
Beside the measured number, compound 3's estimate is 1.8-fold (0.25 log units) above it; low and high end bracket the measured number.
By their numbers in this assay, from the lowest: compounds 2 and 3 (each within the scatter of the next); then compound 1.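

In this assay the step to 4-methylphenyl, a 1.3-fold higher number from compound 2 to compound 3 (0.10 log units; within the scatter), lies within the scatter, so at this position on the ring a methyl reads the same as hydrogen. The step of a 4.0-fold lower number from compound 1 to compound 3 (0.61 log units; beyond the scatter) lies beyond the scatter, which shows that the fluoro and the methyl give clearly different numbers at the same place; among these three compounds, only the fluoro compound stands apart from the other two.

Three groups at one place on the ring cannot show how others would read, such as a methoxy, an amine or a carboxylic acid. From the compounds shown here alone, it also remains open whether a chloro group here would fall with the fluoro compound or with the other two.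

No measurement shown here accounts for the gap between the fluoro and methyl compounds.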